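The source may hold more compounds than are shown below. What is called first, only, known or untested is meant among the compounds shown, and "the series" means these compounds.

Working notes on the series, taken at the cyclobutane-dicarboxamide end.

Compound 1 `Cc1cccc(NC(=O)C2(C(=O)Nc3ccc(Nc4ncc5cc(C(=O)N(C)C)n(C6CCCC6)c5n4)cc3)CC2)c1` carries a 3-methylphenyl amide; in a functional assay on T47D cells (Homo sapiens) for inhibition, read by CCK-8 assay, with a stated time of 72 h, tested at 1 uM (on this read-out higher numbers stand for more inhibition of growth at the one concentration tested and lower numbers for less inhibition of growth), compound 1 gives 45.7%. Compound 2 `CN(C)C(=O)c1cc2cnc(Nc3ccc(NC(=O)C4(C(=O)Nc5cccc(O)c5)CC4)cc3)nc2n1C1CCCC1` has hydroxy in place of methyl on the aromatic carbon, and in this assay compound 2 gives 80.7%. The step is a number 35 percentage points higher from compound 1 to compound 2 (beyond the scatter). Going by the values given here, on the two numbers so far compound 2 stands highest, with compound 1 the nearest and beyond the scatter lower.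

Compound 3 `CN(C)C(=O)c1cc2cnc(Nc3ccc(NC(=O)C4(C(=O)Nc5ccc(C(F)(F)F)cc5)CC4)cc3)nc2n1C1CCCC1` is the next point. Its difference from compound 2 is 4-(trifluoromethyl)phenyl in place of 3-hydroxyphenyl on an amide-type nitrogen. Among the compounds with values here, the only measured step that bears on this is the one from compound 1 to compound 2, which was large and showed that the hydroxy substituent went with the higher growth inhibition. Compound 3 drops that hydroxy, and what enters is a group without a donor or acceptor; nothing measured yet speaks to trifluoromethyl itself. The expectation is therefore a downward step, a number 32.7 percentage points lower from compound 2 to compound 3 (beyond the scatter), of a size comparable to the gain seen from compound 1 to compound 2. In this assay compound 3 is estimated at 48%, with a range from 25% to 70%.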

Compound 3, percent growth inhibition at one concentration: 29.6%
Compound 3: middle estimate off by 18.4 percentage points, on the high side; low and high end bracket the measured number.
By their numbers in this assay, from the lowest: compound 3; then compound 1; then compound 2.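

In this assay the replacement of 3-hydroxyphenyl by 4-(trifluoromethyl)phenyl on the amide-type nitrogen gives a number 51.1 percentage points lower from compound 2 to compound 3 (beyond the scatter), so this position tolerates a change of aryl group poorly when the hydroxy is lost. The hydroxy does not account for all of the spread in this series, since the two aryl groups without it also stand apart: the replacement of 3-methylphenyl by 4-(trifluoromethyl)phenyl gives a number 16.1 percentage points lower from compound 1 to compound 3 (beyond the scatter), and the read-out at this position therefore depends on more than the presence or absence of the hydroxy. Nothing at hand accounts for either step.

In compound 3 the identity of the substituent and its place on the phenyl ring change together, so the compounds shown do not tell which of the two carries the lower growth inhibition. From the compounds shown here alone, it also remains open whether the gain seen with 3-hydroxyphenyl is particular to the hydroxy, or whether an amino group or a methoxy group on the same phenyl ring would keep it.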